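Heptyl in Place of Bromo on a Sulfonamide Scaffold

This account rests on a few compounds, and the source may have more. Where it says the series, first, only, none or still open, it means among the compounds named here.

Compound 1, `CC(C)Cc1ccc(NS(=O)(=O)c2ccc(N3CCNC3=O)cc2)cc1`: > 1000 nM
Compound 2, `O=C1NCCN1c1ccc(S(=O)(=O)Nc2ccc(Br)cc2)cc1`: 300 nM

In a functional assay on HT-29 cells (Homo sapiens) for antiproliferative activity, read by sulforhodamine B assay, with a stated time of 48 h (on this read-out higher numbers stand for weaker inhibition and lower numbers for stronger inhibition), compound 1 reaches only a limit, > 1000 nM. Among the measured compounds shown here, compound 2 gives 300 nM in this assay, the one number among the values shown. The other value shown, that of compound 1, is a limit. Compound 2 thus stands alone as a measured point. The step of an at least 3.3-fold lower number from compound 1 to compound 2 (0.52 log units; beyond the scatter) starts from that limit, and its true size is known only through (the limit of > 1000 nM in this assay, at which 1 of the 2 values shown sits).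

Compound 3, `CCCCCCCc1ccc(NS(=O)(=O)c2ccc(N3CCNC3=O)cc2)cc1`, differs from compound 2 by heptyl in place of bromo on an aromatic carbon. For the measured compounds named here, the only measured step that bears on this change is an at least 3.3-fold lower number from compound 1 to compound 2 (0.52 log units; beyond the scatter), where an alkyl group giving way to bromo lowered the number. The return to an alkyl group, now a longer chain, is therefore expected to raise the number beyond the scatter, possibly back to a limit. For compound 3 the estimate in this assay is 1500 nM, with a range from 400 nM to 6000 nM. This is expected to amount to a step of a 5.0-fold higher number from compound 2 to compound 3 (0.70 log units; beyond the scatter).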

Compound 3, half-maximal inhibitory concentration: > 1000 nM
Compound 3 ended at the assay's limit; the forecaster's own chance of this, stated with the estimate: 55%; the middle value does not contradict the limit.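

In this assay, a second alkyl group at this position behaves as the first did, and the change away from bromo costs activity: an at least 3.3-fold higher number from compound 2 to compound 3 (0.52 log units; beyond the scatter). Compound 3 gives > 1000 nM, which is a limit of the assay and not a number, so among the compounds shown only bromo, in compound 2, yields a measured value, while isobutyl and heptyl do not. No step can be read between compound 1 and compound 3, because both stand at the limit: the limit of > 1000 nM in this assay, at which 2 of the 3 values shown sit.

From the compounds shown here alone, what remains open is how far past that limit the two alkyl compounds truly lie, so the effect of chain length on this position cannot be judged from them. Also open, going by these compounds, is whether chloro, iodo, methoxy or an amine here would match compound 2 or improve on it.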